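Configuration swap at the benzylic carbon of compound 2

This account rests on a few compounds, and the source may have more. Where it says the series, first, only, none or still open, it means among the compounds named here.

Measured in an ADME assay on the whole organism with Oryza sativa as the target, tested at 10 uM; a lower number here means a stronger effect, a higher number a weaker effect of the compound at the concentration tested:
compound 1 `CC(C)c1cccc(NC(=O)N[C@@H](C)c2ccccc2)c1` gives 86%
compound 2 `COc1cccc(NC(=O)N[C@H](C)c2ccccc2)c1` gives 70%

Compound 2 gives the lowest of the two numbers in this assay; the nearest value, that of compound 1, is higher by a gap beyond the usual scatter, so compound 2 shows the stronger effect of the two.

Going by the values given here, compound 3 `COc1cccc(NC(=O)N[C@@H](C)c2ccccc2)c1` has not yet been measured in this assay. the two compounds have the same atoms and bonds and differ only in configuration as drawn: 1 of 1 stereo elements differ; a stereocentre at a saturated chain carbon is drawn R in compound 2 and S in compound 3 No measured pair differs in configuration alone, so no step of this kind is known here, and the value of compound 1 does not isolate it.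

With nothing to anchor the direction, the step from compound 2 to compound 3 is expected to be modest, a number 8 percentage points higher from compound 2 to compound 3 (within the scatter), and not clearly beyond the scatter either way.

Compound 3 is therefore estimated at 78%, with a range from 62% to 94%.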

Compound 3, a percentage reported as activity, at one concentration (the size of the read-out at that concentration, not a potency): 99%
Estimate against measurement, compound 3: 21 percentage points below; measured number outside the range, above it.
By their numbers in this assay, from the lowest: compound 2; then compound 1; then compound 3.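

Inverting the stereocentre at the saturated chain carbon gives a number 29 percentage points higher from compound 2 to compound 3 (beyond the scatter) in this assay and is the first step in the series that isolates configuration, with the form drawn R giving the stronger effect of the pair. The step can be assigned to configuration alone because of one fact: the fact that compounds 2 and 3 differ only in the configuration as drawn. With the form drawn S held fixed, methoxy in place of isopropyl on an aromatic carbon gives a number 13 percentage points higher from compound 1 to compound 3 (beyond the scatter) and so goes with the weaker effect in this pair.

From the compounds shown here alone, the configuration step is read only with methoxy, and whether it holds with isopropyl on the aromatic carbon stays open. Also open, going by these compounds, is how an amine or a carboxylic acid at that aromatic carbon would compare with methoxy and isopropyl.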